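Removing the guanidine-bearing chain: an expected return of activity

The source may hold more compounds than are shown below. What is called first, only, known or untested is meant among the compounds shown, and "the series" means these compounds.

Of the compounds shown here, three sharing one core have been tested in a functional assay on the whole organism (Tail, strain ICR) with Mus musculus as the target, in the tail flick test, with a stated time of 150 min, at a dose of 25 umol/kg by the oral route; on this read-out lower numbers stand for a weaker effect and higher numbers for a stronger effect at the one dose given. Compound 1 `C[C@H](NC(=O)CN(c1nc(Cl)nc2[nH]cnc12)C1CC1)C(=O)OCc1ccccc1` gives 23% in this assay. Compound 2 `CC[C@H](C)[C@H](NC(=O)CN(c1nc(Cl)nc2[nH]cnc12)C1CC1)C(=O)O` gives 6.71%, and compound 3 `N=C(N)NCCC[C@H](NC(=O)CN(c1nc(Cl)nc2[nH]cnc12)C1CC1)C(=O)OCc1ccccc1` gives 6.12%. Compound 3 therefore stands lowest of the three numbers; its value and that of compound 2 lie within the scatter of each other, while compound 1 lies well above it, as the step of a number 16.9 percentage points lower from compound 1 to compound 3 (beyond the scatter) shows.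

The unmeasured compound 4 `CC[C@H](C)[C@H](NC(=O)CN(c1nc(Cl)nc2[nH]cnc12)C1CC1)C(=O)OCc1ccccc1` differs from compound 3 by a group of 4 heavy atoms (4 carbon; no ring) in place of a group of 7 heavy atoms (4 carbon, 3 nitrogen; no ring), on a saturated chain carbon bound to an amide-type nitrogen and a carbonyl carbon. Among the measured compounds shown here, the one measured step that bears on this change runs the other way: from compound 1 to compound 3 a group holding three nitrogen atoms entered on the chain carbon and the number fell, a number 16.9 percentage points lower from compound 1 to compound 3 (beyond the scatter). Compound 4 takes that nitrogen-rich group out again and puts a sec-butyl group in its place, so a rise of similar size is expected, with a number 14.9 percentage points higher from compound 3 to compound 4 (beyond the scatter). Compound 4 is thus estimated at 21%, within a range from 8% to 36%.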

Compound 4, a percentage reported as activity, at one dose (the size of the read-out at that dose, not a potency): 6.9%
The estimate for compound 4 lay 14.1 percentage points above the measured number; the measured number lies below the stated range.
By their numbers in this assay, from the lowest: compounds 3, 2 and 4 (each within the scatter of the next); then compound 1.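

Placing sec-butyl on the saturated chain carbon bound to an amide-type nitrogen and a carbonyl carbon brings no recovery in this assay (a number 0.8 percentage points higher from compound 3 to compound 4 (within the scatter)), and the low number is therefore not tied to the nitrogen-rich chain of compound 3; compound 1, with its methyl, stands apart (a number 16.1 percentage points lower from compound 1 to compound 4 (beyond the scatter)). With sec-butyl at this carbon, benzyl in place of hydrogen on an oxygen next to a carbonyl group makes no visible difference (a number 0.2 percentage points higher from compound 2 to compound 4 (within the scatter)). No measured evidence here accounts for these results.

From the compounds shown here alone, whether the higher number belongs to methyl alone stays open, and a plain hydrogen or an ethyl group on this carbon would test that. Going by these compounds, it is also open whether the benzyl ester matters when methyl sits on this carbon, which the matching carboxylic acid would show.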